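A few compounds are considered here, and "the series" means these few. Any claim that something is new, unique, unknown or untested is made for them only; others in the source may bear on it.

Measured in a functional assay on KB cells (Homo sapiens) for antiproliferative activity, read by sulforhodamine B assay, with a stated time of 3 days; on this read-out higher numbers stand for an effect only at larger amounts of compound and lower numbers for an effect already at smaller amounts:
- compound 1 `CCC1=C(O)c2c(oc(-c3ccc(CC)cc3)cc2=O)C(CC)(CC)C1=O`: 21.9 uM
- compound 2 `CCC1=C(O)c2c(oc(-c3ccc(C(F)(F)F)cc3)cc2=O)C(CC)(CC)C1=O`: 35.7 uM

Compound 2, at 35.7 uM, lies within the usual scatter of compound 1, so these two numbers cannot be told apart. The next compound, compound 3 `CCC1=C(O)c2c(oc(-c3ccc(O)cc3)cc2=O)C(CC)(CC)C1=O`, keeps the shared core and carries hydroxy in place of trifluoromethyl on an aromatic carbon. Among the compounds with values here, only one measured step bears on this change: a 1.6-fold higher number from compound 1 to compound 2 (0.21 log units; within the scatter), with trifluoromethyl in place of ethyl on an aromatic carbon. Within the data shown here, that step stayed within the scatter, but no measured compound carries hydroxy, so the evidence is thin. No clear shift is therefore expected in this assay, and the range must stay wide. The expected change is a 1.4-fold lower number from compound 2 to compound 3 (0.15 log units; within the scatter). For compound 3 the estimated value is 25 uM, with an expected range of 9 uM to 60 uM.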

Compound 3, concentration for half-maximal effect: 20.6 uM
For compound 3 the middle estimate is 1.2-fold (0.08 log units) above the measured one, within the range that was stated.
By their numbers in this assay, from the lowest: compounds 3, 1 and 2 (each within the scatter of the next).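

In this assay, putting hydroxy in place of trifluoromethyl swaps a group of 4 heavy atoms and 0 hydrogen-bond donors for one of 1 heavy atom and 1 hydrogen-bond donor, yet the result is only a 1.7-fold lower number from compound 2 to compound 3 (0.24 log units; within the scatter) and, with hydroxy in place of ethyl, a 1.1-fold lower number from compound 1 to compound 3 (0.03 log units; within the scatter). So on this aromatic carbon, para to a large group, the three groups shown cannot be told apart by this read-out, even though hydroxy is the first of them to carry a hydrogen-bond donor. Nothing measured here explains this lack of separation. As far as these compounds go, whether an amine, a carboxylic acid or a longer chain at this place would move the number beyond the scatter remains open. So does whether hydroxy would behave the same way on a changed version of the shared core.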